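Replacing Benzamido on the Saturated Ring of Compound 2

A few compounds are considered here, and "the series" means these few. Any claim that something is new, unique, unknown or untested is made for them only; others in the source may bear on it.

Measured in an ADME assay on cells (Hepatocyte, Homo sapiens) for metabolic stability, with a stated time of 30 min; a higher number here means that more of the compound is left, a lower number that less of the compound is left:
Compound 1 `CS(=O)(=O)NC1CCC(CN2CCN(c3cc(=O)c4cc(C(F)(F)F)cc([N+](=O)[O-])c4s3)CC2)CC1`: 105%
Compound 2 `O=C(NC1CCC(CN2CCN(c3cc(=O)c4cc(C(F)(F)F)cc([N+](=O)[O-])c4s3)CC2)CC1)c1ccccc1`: 92.9%

Compound 2 stands lower of the two, at 92.9%. Among the compounds with values here, the gap between them is the only measured step: a number 12.1 percentage points lower from compound 1 to compound 2 (beyond the scatter), with benzoyl in place of methylsulfonyl on an amine nitrogen.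

The next compound, compound 3 `Cc1ccc(C(=O)OC2CCC(CN3CCN(c4cc(=O)c5cc(C(F)(F)F)cc([N+](=O)[O-])c5s4)CC3)CC2)cc1`, departs from compound 2 at one place: ((4-methylphenyl)carbonyl)oxy in place of benzamido on a saturated ring carbon. In words, ((4-methylphenyl)carbonyl)oxy stands in place of benzamido on a saturated ring carbon. The measured step bears on this only indirectly, as it changed the group on the amine nitrogen, whereas here the whole benzamido group leaves. Within the data shown here, no measured pair shows this replacement.

Among the measured compounds shown here, compound 2 at 92.9% leaves more room below than above, and a number 12.1 percentage points lower from compound 1 to compound 2 (beyond the scatter) is the only guide to size, so a modest fall in this assay is expected, with wide uncertainty. The expected step is a number 12.9 percentage points lower from compound 2 to compound 3 (beyond the scatter). Compound 3 is estimated at 80%, with an expected range from 55% to 100%.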

Compound 3, percent of the compound remaining: 9.7%
Compound 3: middle estimate off by 70.3 percentage points, on the high side; the whole stated range lies above it.
By their numbers in this assay, from the lowest: compound 3; then compound 2; then compound 1.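

In this assay, the group on the saturated ring carbon turns out to matter far more than the earlier pair suggested: ((4-methylphenyl)carbonyl)oxy in place of benzamido gives a number 83.2 percentage points lower from compound 2 to compound 3 (beyond the scatter), and the same group in place of methanesulfonamido gives a number 95.3 percentage points lower from compound 1 to compound 3 (beyond the scatter), both large steps next to the modest one between the two earlier groups. Among these three compounds, the two that keep a nitrogen on this carbon stay high whether it carries benzoyl or methylsulfonyl, and the low number appears only in compound 3, where an oxygen takes that place and the count of hydrogen-bond donors in the group goes from 1 to 0. Nothing available on these compounds explains the fall, so it stands as an observation only.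

The change to compound 3 alters the linking atom and adds the 4-methyl group together, so these compounds cannot show how much of the step belongs to either. A plain benzoyloxy group, or a benzamido group carrying a methyl on its nitrogen, would separate these parts, and neither is among the compounds shown.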